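A few compounds are considered here, and "the series" means these few. Any claim that something is new, unique, unknown or untested is made for them only; others in the source may bear on it.

Values from an ADME assay on microsomes from liver (Mus musculus) for metabolic stability, read by LC-MS, using NADPH, with stated times of 10 min and 30 min, tested at 1 uM (on this read-out lower numbers stand for slow clearance and higher numbers for fast clearance), follow
Compound 1 (`COC(=O)C1=C(C)NC(c2nccs2)=NC1(C)c1ccc(Cl)cc1`) gives 85 mL/min/kg
Compound 2 (`COC(=O)C1=C(C)NC(c2nccs2)=NC1(C)c1ccc(F)c(F)c1`) gives 83 mL/min/kg
Compound 3 (`COC(=O)C1=C(CN2CCCCC2)NC(c2nccs2)=NC1(C)c1ccc(F)cc1`) gives 88 mL/min/kg

Compound 3 stands level with compound 1 and compound 2, since all three values lie within the usual scatter of one another. Compound 4 (`COC(=O)C1=C(CN2CCOCC2=O)NC(c2nccs2)=NC1(C)c1ccc(F)cc1`) carries 3-oxomorpholin-4-yl in place of piperidin-1-yl on a saturated chain carbon bound to a double-bonded ring carbon. Among the measured compounds shown here, the only measured step (a 1.0-fold lower number from compound 1 to compound 2 (0.01 log units; within the scatter)) concerns a different place, so no measurement speaks directly to this swap, and any forecast is loose. In this assay a modest move to a lower number is expected (a 1.4-fold lower number from compound 3 to compound 4 (0.13 log units; within the scatter)). For compound 4 the estimated value is 65 mL/min/kg (expected range 35 mL/min/kg to 95 mL/min/kg).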

Compound 4, clearance: 80 mL/min/kg
For compound 4 the middle estimate is 1.2-fold (0.09 log units) below the measured one; low and high end bracket the measured number.
By their numbers in this assay, from the lowest: compounds 4, 2, 1 and 3 (each within the scatter of the next).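

In this assay, among the compounds shown here, the first comparison at this position, 3-oxomorpholin-4-yl in place of piperidin-1-yl on a saturated chain carbon bound to a double-bonded ring carbon, gives a 1.1-fold lower number from compound 3 to compound 4 (0.04 log units; within the scatter). So these two six-membered rings, which differ in hetero atoms and in a carbonyl, read alike here. No supporting information accounts for this similarity. For the compounds shown here, with only two rings to compare at this place, it remains open whether a carboxylic acid or an open-chain dimethylamino group there would give a number beyond the scatter.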